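Pyrrolidine in place of dimethylamine on a triazole side chain

A few compounds are considered here, and "the series" means these few. Any claim that something is new, unique, unknown or untested is made for them only; others in the source may bear on it.

Compounds measured so far:
compound 1 `Cc1nnc(CN2CCCC2)n1-c1ccc(Cl)cc1Cc1ccccc1`, 36 mg/kg
compound 2 `Cc1nnc(CN(C)C)n1-c1ccc(Cl)cc1C(=O)c1ccccc1`, 0.5 mg/kg

Both were tested in a functional assay on the whole organism (strain CF-1) for inhibition, with Mus musculus as the target; on this read-out higher numbers stand for an effect only at larger amounts of compound and lower numbers for an effect already at smaller amounts. Compound 2 stands at the lowest of the two numbers, with 0.5 mg/kg, while compound 1 gives 36 mg/kg, a gap that lies well beyond the usual scatter. The two compounds differ in more than one place, so no single step can be read from that pair.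

Compound 3 `Cc1nnc(CN2CCCC2)n1-c1ccc(Cl)cc1C(=O)c1ccccc1` has not been measured yet. It differs from compound 2 in one place only: pyrrolidin-1-yl in place of dimethylamino on a saturated chain carbon bound to an aromatic carbon. The same amine side chain is present in compound 1, but compound 1 also carries a methylene rather than a carbonyl link, so its much higher number cannot be assigned to the amine alone.

Without a measured step for this exchange, the expectation rests on compound 2 as the nearest point. A small shift toward a higher number is expected, and the step from compound 2 to compound 3 is estimated at a 2.4-fold higher number from compound 2 to compound 3 (0.38 log units; beyond the scatter), close to or just past the scatter. Compound 3 is therefore expected to give about 1.2 mg/kg, with a range from 0.3 mg/kg to 5 mg/kg.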

Compound 3, dose for half-maximal effect: 0.4 mg/kg
For compound 3 the middle estimate is 3.0-fold (0.48 log units) above the measured one, within the range that was stated.
By their numbers in this assay, from the lowest: compounds 3 and 2 (each within the scatter of the next); then compound 1.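

In this assay, pyrrolidin-1-yl in place of dimethylamino on a saturated chain carbon bound to an aromatic carbon gives a 1.3-fold lower number from compound 2 to compound 3 (0.10 log units; within the scatter), so in this benzoyl series the ring amine and the open-chain amine cannot be told apart at this position. Compound 3 also provides the single-change comparison that compound 1 and compound 2 could not: benzoyl in place of benzyl on an aromatic carbon gives a 90-fold lower number from compound 1 to compound 3 (1.95 log units; beyond the scatter), a large step, so with the pyrrolidine side chain held constant, the much higher number of compound 1 goes with the benzyl group rather than with the amine. Nothing available explains the size of either step.

The compounds shown leave open whether the tolerance for this exchange extends to other amines, such as piperidine or morpholine, or to a longer chain between the amine and the shared core. They also leave open whether the large benzoyl-to-benzyl difference would appear with dimethylamino on the side chain, and how a hydroxymethylene or sulfonyl link would compare with the carbonyl.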